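This account rests on a few compounds, and the source may have more. Where it says the series, first, only, none or still open, it means among the compounds named here.

Measured so far:
Compound 1, `CCOCc1cc(O)c(O)c(Br)c1Br`: 2510 nM
Compound 2, `O=Cc1cc(Br)c(O)c(O)c1Br`: "not determined" (no result reported)

In a functional assay on HCT-116 cells (Homo sapiens) for cytotoxicity, read by MTT assay, with a stated time of 96 h (a lower number here means a stronger inhibitor, a higher number a weaker inhibitor), compound 1 gives 2510 nM. Compound 2 stands without a number in this assay; its entry reads "not determined" (no result reported), so nothing can be said about how strong or weak it is.

Compound 3 has the structure `OCc1cc(Br)c(O)c(O)c1Br`. It differs from compound 2 in one place: hydroxymethyl in place of formyl on an aromatic carbon. Within the data shown here, with no value for compound 2, there is no measured step to build on, and no direction for this change in this assay can be read from the structures alone; a step of any size, or none beyond the usual scatter, remains possible. The only anchor in this assay is compound 1, which gives 2510 nM.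

On that anchor alone, compound 3 is expected to come in near 3000 nM, with a range from 700 nM to 13000 nM.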

Compound 3, half-maximal inhibitory concentration: 21400 nM
Estimate against measurement, compound 3: 7.1-fold (0.85 log units) below; the whole stated range lies below it.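

Compound 2 has no number to set beside compound 3, so no step can be read for hydroxymethyl in place of formyl. Going by these compounds, whether that change strengthens or weakens inhibition in this assay stays open. No available evidence bears on this result.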